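The source may report more compounds than this note shows. Statements on the series, on what has been measured and on what is new or still open speak of the compounds shown alone.

The compounds share one core, a naphthalene sulfonamide joined through a short hydroxylated chain to an amine, and they differ only in what that amine carries. Compound 1 `CC(C)CC1CCCN1C[C@@H](O)CNS(=O)(=O)c1cccc2ccccc12` carries a substituted five-membered ring on the amine. In an assay on HEK293 cells for inhibition of sodium- and chloride-dependent glycine transporter 1 (Homo sapiens) (on this read-out lower numbers stand for stronger inhibition and higher numbers for weaker inhibition), compound 1 gives 2510 nM; 6310 nM (2 entries), two separate entries (the several entries of compound 1 in this assay, 2510 nM; 6310 nM (2 entries)). Compound 2 `CCCN(C[C@@H](O)CNS(=O)(=O)c1cccc2ccccc12)C(C)CC` carries an open-chain amine instead. In this assay compound 2 gives 1260 nM, the only numeric entry for it; one further entry for compound 2 carries no single number. Compound 3 `CCC1CCCCN1C[C@@H](O)CNS(=O)(=O)c1cccc2ccccc12` has not yet been measured. The change from compound 2 to compound 3 is 2-ethylpiperidin-1-yl in place of propyl(sec-butyl)amino on a saturated chain carbon, two bonds along the chain from an oxygen on a saturated carbon. Among the compounds with values here, no measured pair shows this kind of step. The ring-bearing compound 1 and the open-chain compound 2 give numbers that lie close together, so the step expected from compound 2 to compound 3 is a 1.6-fold higher number from compound 2 to compound 3 (0.20 log units; within the scatter), small and within the usual scatter. Compound 3 is therefore estimated at 2000 nM, with a likely range from 600 nM to 6500 nM.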

Compound 3, half-maximal inhibitory concentration: 7940 nM
Compound 3: the middle estimate sits 4.0-fold (0.60 log units) below what was measured; the whole stated range lies below it.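

In this assay, within the data shown here, replacing propyl(sec-butyl)amino with 2-ethylpiperidin-1-yl gives a 6.3-fold higher number from compound 2 to compound 3 (0.80 log units; beyond the scatter), the first measured step at this position on the saturated chain carbon. The two groups have the same heavy-atom count, the same atoms, and the same counts of hydrogen-bond donors and acceptors, and neither carries a net charge, so the listed counts that separate them are the ring in the entering group and its absence in the leaving one. Thus, the result shows that inhibition at this position is not set by those matching counts alone, while the spread within the ring-bearing compound 1 is a reminder that a single entry for compound 3 gives only a limited view of its value: the several entries of compound 1 in this assay, 2510 nM; 6310 nM (2 entries)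

The compounds shown leave open whether the higher number for compound 3 goes with closing the ring or with the ethyl group on it, and a plain piperidin-1-yl group would help separate those two possibilities. They also leave open how a longer open chain on the amine would compare with the propyl and sec-butyl groups of compound 2.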